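This account rests on a few compounds, and the source may have more. Where it says the series, first, only, none or still open, it means among the compounds named here.

- compound 1 `Cc1ccnc(NC(c2ccccc2F)c2ccc3cccnc3c2O)c1`: 13100 nM
- compound 2 `Cc1ccnc(NC(c2ccccc2)c2ccc3cccnc3c2O)c1`: > 10000 nM

Both compounds were tested in a functional assay on U-87MG ATCC cells for inhibition, with U-87 MG (Homo sapiens) as the target, read by MTT assay, with a stated time of 72 h; a lower number here means a stronger inhibitor, a higher number a weaker inhibitor. Compound 2 is reported only as a limit, > 10000 nM, so it has no exact number. This is the limit of > 10000 nM in this assay, at which 1 of the 2 values shown sits.

The next compound, compound 3 `Cc1ccnc(NC(c2cccc(F)c2)c2ccc3cccnc3c2O)c1`, puts fluoro in place of hydrogen on an aromatic carbon, meta to a large group, turning phenyl into 3-fluorophenyl: fluoro in place of hydrogen on an aromatic carbon.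

Within the data shown here, the one measured comparison that bears on this is a step that the limit leaves unreadable from compound 1 to compound 2, the opposite swap, with the fluoro elsewhere on that ring. It gives no size and no direction to carry over. No step beyond the scatter is therefore expected in this assay, and compound 3 should stay close to compound 1 with 13100 nM. The expected change is a step that the limit leaves unreadable from compound 2 to compound 3. The estimate for compound 3 is 12000 nM, with an expected range of 5000 nM to 30000 nM.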

Compound 3, half-maximal inhibitory concentration: 9200 nM
The estimate for compound 3 lay 1.3-fold (0.12 log units) above the measured number; low and high end bracket the measured number.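

In this assay, among these compounds, the first readable comparison on this ring is between its two fluorinated forms, 2-fluorophenyl and 3-fluorophenyl, and it gives a 1.4-fold lower number from compound 1 to compound 3 (0.15 log units; within the scatter). These two placements of the fluoro therefore cannot be told apart in this assay. Fluoro in place of hydrogen at the new place gives only a floor, an at least 1.0-fold lower number from compound 2 to compound 3 (0.03 log units; that floor lies within the scatter), so the size of any effect of adding fluoro stays unknown, and compound 2 is a limit rather than a number: the limit of > 10000 nM in this assay, at which 1 of the 3 values shown sits.

The compounds shown leave open whether any group on this ring gives a number clearly apart from these. A chlorine, a methoxy group or an amine in the place of the fluoro would test this.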